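The compounds below may be only part of what the source reports. "The series", "measured", "known", "first", "only" and "open" are said of these compounds alone.

In a functional assay on the whole organism with Mus musculus as the target (on this read-out lower numbers stand for an effect already at smaller amounts and higher numbers for an effect only at larger amounts of compound), two compounds sharing one core have been measured so far. Compound 1 `C[C@@H](NCc1ccc(OCc2ccccc2Cl)cc1)C(N)=O` gives 17.4 mg/kg, while compound 2 `C[C@@H](NCc1ccc(OCC2CC2)cc1)C(N)=O` gives 124 mg/kg, the higher of the two numbers and the weaker result. Compound 3 `C[C@@H](NCc1ccc(OCC2CCCCC2)cc1)C(N)=O` keeps the core of compound 2 and alters one group: cyclohexyl in place of cyclopropyl on a saturated chain carbon bound to an oxygen on an aromatic ring. Among the measured compounds shown here, the one measured step that bears on this change is a 7.1-fold higher number from compound 1 to compound 2 (0.85 log units; beyond the scatter), beyond the scatter, with cyclopropyl entering in place of 2-chlorophenyl on the same saturated chain carbon. For the measured compounds named here, compound 3 gives up that cyclopropyl for a larger carbon ring, so a partial return towards the number of compound 1 is expected, though no measurement yet tests cyclohexyl here. In this assay, the expected change is a 3.1-fold lower number from compound 2 to compound 3 (0.49 log units; beyond the scatter), towards a lower number. For compound 3, the estimated value is 40 mg/kg, with an expected range from 14 mg/kg to 115 mg/kg.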

Compound 3, dose for half-maximal effect: 131 mg/kg
Compound 3: the middle estimate sits 3.3-fold (0.52 log units) below what was measured; measured number outside the range, above it.
By their numbers in this assay, from the lowest: compound 1; then compounds 2 and 3 (each within the scatter of the next).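

In this assay the step shows a 1.1-fold higher number from compound 2 to compound 3 (0.02 log units; within the scatter) at this position, so going from cyclopropyl to cyclohexyl on the saturated chain carbon bound to an oxygen on an aromatic ring brings no change that can be read. The second step, a 7.5-fold higher number from compound 1 to compound 3 (0.88 log units; beyond the scatter), shows that the larger ring stays as far from the 2-chlorophenyl result as cyclopropyl did, which means that ring size alone among these carbon rings does not recover the number of compound 1. Nothing measured here explains this result.

The compounds shown leave open whether the gap to compound 1 rests on the chlorine or on the phenyl ring itself, which a plain phenyl at this place would separate. They also leave open how a 2-fluorophenyl or a 2-methylphenyl group would read here.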